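Aryl variation on the shared core: next step to compound 4

The source may hold more compounds than are shown below. What is called first, only, known or untested is meant among the compounds shown, and "the series" means these compounds.

Measured so far:
compound 1 `CCCS(=O)(=O)Nc1ccc(F)c(C(=O)c2n[nH]c3ncc(-c4cccc(F)c4)cc23)c1F` — 8.2%
compound 2 `CCCS(=O)(=O)Nc1ccc(F)c(C(=O)c2n[nH]c3ncc(-c4ccccc4O)cc23)c1F` — 9%
compound 3 `CCCS(=O)(=O)Nc1ccc(F)c(C(=O)c2n[nH]c3ncc(-c4cccc(N)c4)cc23)c1F` — 1.6%

All three were read in an assay for binding affinity to dual specificity mitogen-activated protein kinase kinase 4 (Homo sapiens), read by KINOMEscan, tested at 100 nM; a higher number here means a weaker effect of the compound at the concentration tested, a lower number a stronger effect. Compound 3 gives the lowest of the three numbers, yet each step to it stays within the usual scatter: a number 6.6 percentage points lower from compound 1 to compound 3 (within the scatter) and a number 7.4 percentage points lower from compound 2 to compound 3 (within the scatter). The third pair is likewise flat: a number 0.8 percentage points higher from compound 1 to compound 2 (within the scatter).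

Compound 4 `CCCS(=O)(=O)Nc1ccc(F)c(C(=O)c2n[nH]c3ncc(-c4ccc(S(=O)(=O)NC)cc4)cc23)c1F` is not yet measured. Its change from compound 3 is 4-(methylsulfamoyl)phenyl in place of 3-aminophenyl on an aromatic carbon. All three measured steps alter the same aryl group and none left the scatter, so no step beyond the scatter is expected here either, in no particular direction. The estimated step is a number 4.4 percentage points higher from compound 3 to compound 4 (within the scatter). For compound 4 the expected value in this assay is 6%, within 1% to 20%.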

Compound 4, a percentage reported as activity, at one concentration (the size of the read-out at that concentration, not a potency): 1.2%
Compound 4: middle estimate off by 4.8 percentage points, on the high side; the measured number falls inside the stated range.
By their numbers in this assay, from the lowest: compounds 4, 3, 1 and 2 (each within the scatter of the next).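

The larger 4-(methylsulfamoyl)phenyl group, which brings a sulfur-containing substituent to this aryl position, still leaves the number in this assay flat: a number 0.4 percentage points lower from compound 3 to compound 4 (within the scatter), a number 7.8 percentage points lower from compound 2 to compound 4 (within the scatter) and a number 7 percentage points lower from compound 1 to compound 4 (within the scatter). Across the four aryl groups shown, therefore, neither this change nor any earlier one has left the scatter. Nothing at hand gives a reason for this flatness.

Still open, as far as these compounds go, is whether a carboxylic acid or a piperazine on this aryl ring would move the number beyond the scatter. The same question stands for replacing the aryl group with a plain alkyl chain.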